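The compounds below may be only part of what the source reports. "The series", "measured", "known", "first", "only" and "open" are said of these compounds alone.

Going by the values given here, in a functional assay on M21 cells (Homo sapiens) for antiproliferative activity, read by sulforhodamine B assay, with a stated time of 48 h (a lower number here means a stronger inhibitor, a higher number a weaker inhibitor), compound 1 `Cc1cccc(NS(=O)(=O)c2ccc(N3CCNC3=O)cc2)c1` gives 69 nM, the lowest of the two numbers measured so far. Compound 2 `O=C1NCCN1c1ccc(S(=O)(=O)Nc2ccc(Br)cc2)cc1` gives 130 nM in this assay, and the step is a 1.9-fold higher number from compound 1 to compound 2 (0.28 log units; within the scatter). Compound 3 `Cc1ccc(NS(=O)(=O)c2ccc(N3CCNC3=O)cc2)c(C)c1` differs from compound 1 by 2,4-dimethylphenyl in place of 3-methylphenyl on a sulfonamide nitrogen. Among the compounds with values here, the only measured step that bears on this change is the swap of one aryl group for another on a sulfonamide nitrogen, from compound 1 to compound 2, which stayed within the scatter, so no step beyond the scatter is expected here in either direction. Compound 3 is therefore estimated at 80 nM, with a range of 35 nM to 180 nM. For compound 3 the expected step is a 1.2-fold higher number from compound 1 to compound 3 (0.06 log units; within the scatter).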

Compound 3, half-maximal inhibitory concentration: 150 nM
Beside the measured number, compound 3's estimate is 1.9-fold (0.27 log units) below it; low and high end bracket the measured number.
By their numbers in this assay, from the lowest: compounds 1, 2 and 3 (each within the scatter of the next, the first and the last beyond it).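

Going by these compounds alone, on the sulfonamide nitrogen, 2,4-dimethylphenyl in place of 3-methylphenyl is the first change at this position to clear the scatter in this assay (a 2.2-fold higher number from compound 1 to compound 3 (0.34 log units; beyond the scatter)). In place of 4-bromophenyl, the same group does not separate (a 1.2-fold higher number from compound 2 to compound 3 (0.06 log units; within the scatter)), so the aryl group here matters only modestly, and only compound 1 and compound 3 stand apart. Nothing measured here explains this shift. Still open, as far as these compounds go, is whether a pyridine ring, or an aryl ring carrying an amine or a carboxylic acid, would move the number further in either direction.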